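A Benzyl Swap on the Nitrogen Substituent

The compounds below may be only part of what the source reports. "The series", "measured", "known", "first", "only" and "open" are said of these compounds alone.

Compound 1 `Cc1ccccc1Nc1nc(Nc2cccnc2)ncc1Cl` gives 38600 nM
Compound 2 `Cc1ccc(Nc2ncc(Cl)c(Nc3ccccc3C)n2)cc1` gives > 100000 nM, which is a limit of the assay

For the measured compounds named here, in a functional assay on Jurkat cells (Homo sapiens) for inhibition, read by CCK-8 assay, with a stated time of 48 h (a higher number here means a weaker inhibitor of growth, a lower number a stronger inhibitor of growth), compound 1 gives 38600 nM, the only actual number so far. The other result, for compound 2, is a limit. Compound 3 `Cc1ccccc1Nc1nc(NCc2ccccc2)ncc1Cl` has benzyl in place of pyridin-3-yl on a nitrogen on an aromatic ring. Like compound 3, compound 2 loses the six-membered aromatic ring with 1 hetero atom and carries a ring of carbon only. That single measured step bears on the change, showing an at least 2.5-fold higher number from compound 1 to compound 2 (0.41 log units; beyond the scatter). From the compounds shown here alone, it points towards a higher number, though its true size is unknown and benzyl is a different group. A moderate rise is therefore expected, estimated as a 1.6-fold higher number from compound 1 to compound 3 (0.19 log units; within the scatter). For compound 3 the expected value is 60000 nM, with an estimated range from 22000 nM to 120000 nM.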

Compound 3, concentration for 50% growth inhibition: > 100000 nM
Compound 3 ended at the assay's limit (the forecaster's own chance of this, stated with the estimate: 40%); middle value at least 1.6-fold (0.22 log units) from the limit.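

In this assay, benzyl in place of pyridin-3-yl on this nitrogen gives an at least 2.5-fold higher number from compound 1 to compound 3 (0.41 log units; beyond the scatter). With 4-methylphenyl in compound 2 and benzyl in compound 3, both carbon-only ring groups shown at this position move the same way, and compound 1 alone keeps a measured number. Compound 2 and compound 3 each stand at a limit, not a number, so the step between them cannot be read and benzyl cannot be ranked against 4-methylphenyl: the limit of > 100000 nM in this assay, at which 2 of the 3 values shown sit.

The compounds shown leave open whether the ring nitrogen of pyridin-3-yl matters in itself, since compound 3 also adds a carbon to the group, and a pyridin-3-ylmethyl group would separate these two changes. Also open, from the compounds shown here alone, is whether an amine or a carboxylic acid carried on this ring would give a measured number.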